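From 4-Methylphenyl to 4-Ethylphenyl: Expected Cytotoxicity

A few compounds are considered here, and "the series" means these few. Any claim that something is new, unique, unknown or untested is made for them only; others in the source may bear on it.

Of the compounds shown here, three built on one shared core have so far been tested in an ADME assay on Vero cells (Chlorocebus sabaeus) for cytotoxicity, read by resazurin assay, with a stated time of 3 days; on this read-out lower numbers stand for stronger inhibition and higher numbers for weaker inhibition. Compound 3 `CCN(CC)c1cc2[nH]c(C3CCCCC3)nc2cc1NC(=O)c1ccc(C)cc1` gives > 100 ug/mL in this assay, which is a limit of the assay and not a measured number. Compound 2 `CCCCNC(=O)Nc1cc2nc(C3CCCCC3)[nH]c2cc1N(CC)CC` gives > 100 ug/mL in this assay, again a limit. Compound 1 `CCN(CC)c1cc2[nH]c(C3CCCCC3)nc2cc1NC(=O)c1ccc(N(C)C)cc1` has "not determined" (no result reported) in this assay. Among the measured compounds shown here, the one step between measured compounds differing in a single place, a step that the two limits leave unreadable from compound 2 to compound 3, is therefore a step that the two limits leave unreadable. For the measured compounds named here, the only evidence on the measured steps is the limit of > 100 ug/mL in this assay, at which 2 of the 3 values shown sit.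

Compound 4 `CCc1ccc(C(=O)Nc2cc3nc(C4CCCCC4)[nH]c3cc2N(CC)CC)cc1` is the next compound to be measured. It differs from compound 3 by methyl in place of hydrogen on a saturated chain carbon bound to an aromatic carbon; cut one bond further out, the change reads 4-methylphenyl to 4-ethylphenyl. Going by the values given here, no measured step bears readably on this change, since the step from compound 2 to compound 3 has no readable size. The expectation therefore rests on the shared position of compound 2 and compound 3 at the limit, and the expected step that the limit leaves unreadable from compound 3 to compound 4 is none beyond the scatter. Compound 4 is estimated to give 150 ug/mL in this assay, with a likely range from 60 ug/mL to 400 ug/mL.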

Compound 4, half-maximal inhibitory concentration: > 100 ug/mL
Compound 4 was reported as a limit (the forecaster's own chance of this, stated with the estimate: 80%); the middle value is on the limit's open side.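

Compound 4 gives > 100 ug/mL in this assay, which is a limit of the assay and not a measured number. No new step can be read among compound 2, compound 3 and compound 4, as all three stand at the same limit: the limit of > 100 ug/mL in this assay, at which 3 of the 4 values shown sit. The compounds shown leave open how large any difference between these three compounds is in this assay.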